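Swapping a chlorophenyl for a dimethoxyphenyl on the hydrazone

This account rests on a few compounds, and the source may have more. Where it says the series, first, only, none or still open, it means among the compounds named here.

Compound 1, `O=C(N/N=C/c1cccc(F)c1)c1cccnc1Nc1cccc(C(F)(F)F)c1`: in a functional assay on the whole organism (strain Wistar) for inhibition, with Rattus norvegicus as the target, read by paw edema, with a stated time of 30 min, at a dose of 10 mg/kg by the intraperitoneal route (on this read-out lower numbers stand for less inhibition and higher numbers for more inhibition at the one dose given (going by the name of the read-out)), compound 1 gives 58.3%.
Compound 2, `O=C(N/N=C/c1ccc(F)cc1)c1cccnc1Nc1cccc(C(F)(F)F)c1`: in this assay compound 2 gives 33.9%.
Compound 3, `O=C(N/N=C/c1ccc(Cl)cc1)c1cccnc1Nc1cccc(C(F)(F)F)c1`: in this assay compound 3 gives 52.4%.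

Compound 3 stands second highest of these three numbers. Its gap to compound 1 lies within the scatter (a number 5.9 percentage points lower from compound 1 to compound 3 (within the scatter)), while its gap to compound 2 lies beyond it (a number 18.5 percentage points higher from compound 2 to compound 3 (beyond the scatter)). Compound 4, `COc1ccc(/C=N/NC(=O)c2cccnc2Nc2cccc(C(F)(F)F)c2)c(OC)c1`, has not yet been measured. It differs from compound 3 in one place: 2,4-dimethoxyphenyl in place of 4-chlorophenyl on a carbon with a double bond to nitrogen.

All three measured steps change the same ring on the carbon double-bonded to nitrogen: a number 24.4 percentage points lower from compound 1 to compound 2 (beyond the scatter), a number 18.5 percentage points higher from compound 2 to compound 3 (beyond the scatter) and a number 5.9 percentage points lower from compound 1 to compound 3 (within the scatter). None of them involves a methoxy group, so they only show how far this ring's substituent has shifted the read-out so far. I therefore expect compound 4 to fall inside that span, with an estimated step of a number 7.4 percentage points lower from compound 3 to compound 4 (within the scatter) that is not clearly beyond the scatter. My estimate for compound 4 is 45%, ranging from 25% to 65%.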

Compound 4, a percentage reported as inhibition, in the whole organism at one dose (the size of the read-out at that dose, not a potency): 37.8%
Beside the measured number, compound 4's estimate is 7.2 percentage points above it, and the stated range covers the measured number.
By their numbers in this assay, from the lowest: compounds 2 and 4 (each within the scatter of the next); then compounds 3 and 1 (each within the scatter of the next).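

For the compounds shown here, the 2,4-dimethoxyphenyl ring is the first group at this position that carries oxygen, and in this assay it gives a lower number than 4-chlorophenyl (a number 14.6 percentage points lower from compound 3 to compound 4 (beyond the scatter)) and 3-fluorophenyl (a number 20.5 percentage points lower from compound 1 to compound 4 (beyond the scatter)). Against 4-fluorophenyl, no clear difference appears (a number 3.9 percentage points higher from compound 2 to compound 4 (within the scatter)), so the read-out does not separate this ring with two methoxy groups from a ring with a single fluoro group. Nothing here explains why these rings give different numbers.

From the compounds shown here alone, it remains open how a ring bearing an amine or a carboxylic acid would score at this position. Going by these compounds, it is also open whether one methoxy group alone would give a number like that of the 2,4-dimethoxyphenyl ring, and each number, taken at one dose, says nothing about potency.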